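Chloropyridinyl ether isomers: solubility notes

A few compounds are considered here, and "the series" means these few. Any claim that something is new, unique, unknown or untested is made for them only; others in the source may bear on it.

Two compounds of the series have a number in a physicochemical assay for solubility, read by HPLC, measured as thermodynamic solubility, with a stated time of 4 h, at pH 6.8 (on this read-out lower numbers stand for lower solubility and higher numbers for higher solubility), so far. Compound 1, `Cn1c(COc2cccc(C(=O)O)c2)nc2ccc(Oc3ccc(Cl)c(F)c3)nc21`, gives 1.7 ug/mL in this assay. Compound 2, `Cn1c(COc2cccc(C(=O)O)c2)nc2ccc(Oc3cccc(Cl)n3)cc21`, gives 7.7 ug/mL, the higher of the two numbers; the gap to compound 1 lies beyond the usual scatter of this assay, and compound 2 stands at the top of what has been measured.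

Compound 3, `Cn1c(COc2cccc(C(=O)O)c2)nc2ccc(Oc3ncccc3Cl)cc21`, is not yet measured. It differs from compound 2 in one place: 3-chloropyridin-2-yl in place of 6-chloropyridin-2-yl on an oxygen on an aromatic ring; the two compounds have the same atoms, joined differently. For the measured compounds named here, no step of this kind between measured compounds is on hand, so there is nothing to anchor the size of the move. Going by the values given here, the expectation is a step from compound 2 to compound 3 of a 1.3-fold lower number from compound 2 to compound 3 (0.11 log units; within the scatter), which may be no step at all beyond the scatter, in either direction. On that basis compound 3 is estimated at 6 ug/mL in this assay, within a range from 2 ug/mL to 20 ug/mL, the wide range reflecting the lack of a comparable step.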

Compound 3, solubility: 15 ug/mL
Compound 3: the middle estimate sits 2.5-fold (0.40 log units) below what was measured, and the stated range covers the measured number.
By their numbers in this assay, from the lowest: compound 1; then compounds 2 and 3 (each within the scatter of the next).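

For the compounds shown here, the exchange of 6-chloropyridin-2-yl for 3-chloropyridin-2-yl on an oxygen on an aromatic ring supplies the only step that can be read so far in this assay (a 1.9-fold higher number from compound 2 to compound 3 (0.29 log units; within the scatter)), and this step lies within the scatter. For this position, the result shows that these two isomers, with the same atoms joined differently, cannot be told apart on this read-out, so this exchange gives no basis for ranking compound 2 and compound 3. Nothing on hand bears on why the two isomers read as they do.

Going by these compounds alone, compound 1 differs from compound 2 and compound 3 in more than one place, so no step to it can be read, and the contribution of the group on the oxygen to the printed values of the series remains unresolved. Also open, from the compounds shown here alone, is whether a chloropyridinyl ring carrying an amine or a carboxylic acid in place of the chlorine, tested on the same core and at the same position, would give a step beyond the scatter in this assay rather than one within it.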